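Benzyloxy in place of ethoxy on a shared core

The source may report more compounds than this note shows. Statements on the series, on what has been measured and on what is new or still open speak of the compounds shown alone.

Compound 2 `CCOc1ccc2c(NCCN(C)C)ccnc2c1` gives 2570 nM in a functional assay on HCT-116 cells (Homo sapiens) for cytotoxicity, read by MTT assay, with a stated time of 48 h (on this read-out lower numbers stand for stronger inhibition and higher numbers for weaker inhibition), the highest of the two numbers measured; compound 1 `CN(C)CCNc1ccnc2cc(OCc3ccc(F)cc3)ccc12` gives 370 nM in this assay. Compound 3 `CN(C)CCNc1ccnc2cc(OCc3ccccc3)ccc12` differs from compound 2 by phenyl in place of methyl on a saturated chain carbon bound to an oxygen on an aromatic ring. Among the compounds with values here, the only measured step bearing on this change is a 6.9-fold higher number from compound 1 to compound 2 (0.84 log units; beyond the scatter), which runs the other way, methyl in place of 4-fluorophenyl, at the same place. Reversing that step, compound 3 is expected to show a lower number, a step of a 5.7-fold lower number from compound 2 to compound 3 (0.76 log units; beyond the scatter). The number expected for compound 3 lies close to that of compound 1, which gives 370 nM. Compound 3 is therefore estimated at 450 nM, with a range from 200 nM to 1000 nM.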

Compound 3, half-maximal inhibitory concentration in the HCT-116 assay: 1980 nM
Compound 3: the middle estimate sits 4.4-fold (0.64 log units) below what was measured, and the stated range ends below it.
By their numbers in the HCT-116 assay, from the lowest: compound 1; then compounds 3 and 2 (each within the scatter of the next).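

In the HCT-116 assay, phenyl in place of methyl on this saturated chain carbon gives a 1.3-fold lower number from compound 2 to compound 3 (0.11 log units; within the scatter) and so stays within the scatter, while hydrogen in place of fluoro on an aromatic carbon gives a 5.4-fold higher number from compound 1 to compound 3 (0.73 log units; beyond the scatter) and is the step here that goes beyond it. In a physicochemical assay for solubility (a lower number here means a less soluble compound, a higher number a more soluble compound), compound 2 gives > 10000 ug/mL as a limit of the assay. In the physicochemical assay compound 3 gives > 10000 ug/mL as a limit too, and the step between these two compounds cannot be read: the limit of > 10000 ug/mL in the physicochemical assay, at which 2 of the 2 values shown sit.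

Within the data shown here, only this one pair bears on fluoro, so it stays open whether, in the HCT-116 assay, chloro or methoxy in place of fluoro on that aromatic carbon would match compound 1.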